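Halogen swap on the sulfonyl aryl ring in a dienone series

The source may hold more compounds than are shown below. What is called first, only, known or untested is meant among the compounds shown, and "the series" means these compounds.

The measured compounds, each with its value in a functional assay on HepG2 cells (Homo sapiens) for cytotoxicity, read by MTT assay, with a stated time of 24 h; on this read-out higher numbers stand for weaker inhibition and lower numbers for stronger inhibition:
compound 1, `O=C1/C(=C/c2cccc(F)c2)CN(S(=O)(=O)c2ccc(Cl)cc2)C/C1=C\c1cccc(F)c1`, gives 13100 nM;
compound 2, `O=C1/C(=C/c2cccc(F)c2)CN(S(=O)(=O)c2ccc(Br)cc2)C/C1=C\c1cccc(F)c1`, gives 7700 nM;
compound 3, `O=C1/C(=C/c2ccc(F)cc2)CN(S(=O)(=O)c2ccc(Cl)cc2)C/C1=C\c1ccc(F)cc1`, gives 4500 nM.

Compound 1 and compound 2 share one core and differ in one place: bromo in place of chloro on an aromatic carbon. On that change the read-out moved by a 1.7-fold lower number from compound 1 to compound 2 (0.23 log units; within the scatter), a step that the usual scatter of repeated measurements can account for on its own. Compound 3 carries the same atoms as compound 1 joined differently; how the two cores differ is not broken down here. What the two values show is that compound 3 sits clearly lower than compound 1 in this assay, while compound 3 and compound 2 lie within the scatter of each other.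

Compound 4, `O=C1/C(=C/c2ccc(F)cc2)CN(S(=O)(=O)c2ccc(Br)cc2)C/C1=C\c1ccc(F)cc1`, has not yet been measured. It stands to compound 3 as compound 2 stands to compound 1: bromo in place of chloro on an aromatic carbon, and the surroundings of the place are described in the same words for both pairs, so this is the same change, seen a second time. Going by the values given here, because the earlier instance gave a 1.7-fold lower number from compound 1 to compound 2 (0.23 log units; within the scatter), compound 4 is expected to show a step of a 1.5-fold lower number from compound 3 to compound 4 (0.18 log units; within the scatter) from compound 3, with the single prior example as the only ground. Compound 4 is therefore estimated at 3000 nM, within a range from 1400 nM to 6500 nM.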

Compound 4, half-maximal inhibitory concentration: 8000 nM
Compound 4: middle estimate off by 2.7-fold (0.43 log units), on the low side; the whole stated range lies below it.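

In this assay, bromo in place of chloro on an aromatic carbon, para to a large group, gives a 1.8-fold higher number from compound 3 to compound 4 (0.25 log units; within the scatter), a step that the usual scatter of repeated measurements could account for if taken alone. Set beside the earlier instance, the new step runs the opposite way, and the gap between the two is wider than the scatter of two such steps, so in this series the change cannot be carried from one core to the other as a fixed step: the same change on two cores in this assay, a 1.7-fold lower number (0.23 log units; within the scatter) from compound 1 to compound 2 and a 1.8-fold higher number (0.25 log units; within the scatter) from compound 3 to compound 4, 3.0-fold (0.48 log units) apart, beyond the scatter of two such steps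

This does not show that either core truly prefers one halogen, as each step on its own lies within the scatter, and it does not show what in the two cores separates the results or how the change would behave on a third core.

The compounds shown leave open whether anything other than chloro or bromo at this place would give a clearer step in this assay, for instance fluoro, methoxy or a plain hydrogen. They also leave open how an amine or a carboxylic acid would read there, on either of the two cores.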